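Swapping the terminal ring at the amine nitrogen

This account rests on a few compounds, and the source may have more. Where it says the series, first, only, none or still open, it means among the compounds named here.

Measured compounds:
compound 1, `c1ccc(CNCCCCN(C[C@H]2Cc3ccccc3CN2)[C@H]2CCCc3cccnc32)cc1`, 20.1 nM
compound 2, `c1ccc2c(c1)CN[C@@H](CN(CCCCNCC1CCNCC1)[C@H]1CCCc3cccnc31)C2`, 36.5 nM
compound 3, `O=S1(=O)CCC(CNCCCCN(C[C@H]2Cc3ccccc3CN2)[C@H]2CCCc3cccnc32)CC1`, 17 nM

All three share one core and differ only in the group carried by the terminal amine nitrogen. In a functional assay on cells for antagonist activity at C-X-C chemokine receptor type 4 (Homo sapiens), read by fluorescence and calcium flux, with stated times of 25 min and 90 s (a lower number here means a stronger inhibitor, a higher number a weaker inhibitor), compound 3 gives the lowest of the three numbers; its gap to compound 1 is within the scatter, while the step of a 2.1-fold lower number from compound 2 to compound 3 (0.33 log units; beyond the scatter) is modest but beyond it. Compound 4, `c1ccc2c(c1)CN[C@@H](CN(CCCCNC1CCCCC1)[C@H]1CCCc3cccnc31)C2`, is not yet measured. Its change from compound 3 is cyclohexyl in place of (1,1-dioxothian-4-yl)methyl on an amine nitrogen: the carbon linking the ring to the nitrogen is gone, and the ring with two hydrogen-bond acceptors becomes one of carbon only.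

Within the data shown here, the measured steps that bear on this are a 1.2-fold lower number from compound 1 to compound 3 (0.07 log units; within the scatter) and a 2.1-fold lower number from compound 2 to compound 3 (0.33 log units; beyond the scatter), both small; each changes only the ring, never the link to the nitrogen, so no step directly covers the change to compound 4. Given that all three rings gave similar numbers, compound 4 is expected to land near compound 3, with the step of a 1.8-fold higher number from compound 3 to compound 4 (0.25 log units; within the scatter) estimated as small and uncertain in direction. Compound 4 is therefore estimated at 30 nM, with a range from 10 nM to 90 nM.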

Compound 4, half-maximal inhibitory concentration: 75.2 nM
Compound 4: middle estimate off by 2.5-fold (0.40 log units), on the low side; the range from low to high includes it.
By their numbers in this assay, from the lowest: compounds 3, 1 and 2 (each within the scatter of the next, the first and the last beyond it); then compound 4.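

In this assay, benzyl, (piperidin-4-yl)methyl and (1,1-dioxothian-4-yl)methyl on the terminal amine nitrogen gave numbers that lie close together, so this position seemed to tolerate a change of ring. Cyclohexyl shows that it does not tolerate every change, with a 4.4-fold higher number from compound 3 to compound 4 (0.65 log units; beyond the scatter), a 3.7-fold higher number from compound 1 to compound 4 (0.57 log units; beyond the scatter) and a 2.1-fold higher number from compound 2 to compound 4 (0.31 log units; beyond the scatter), which leaves compound 4 as the weakest inhibitor of the four. Unlike the earlier steps, this change also removes the carbon linking the ring to the nitrogen, and all three steps to compound 4 are modest but beyond the scatter.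

The compounds shown do not separate the loss of that linking carbon from the change of ring, a question that cyclohexylmethyl on the same nitrogen would address. Nothing given here explains the higher number of compound 4.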